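Aryl swap at the four-membered ring: compound 2 to compound 3

A few compounds are considered here, and "the series" means these few. Any claim that something is new, unique, unknown or untested is made for them only; others in the source may bear on it.

Measured so far:
compound 1 `COc1ccc([C@@H]2[C@@H](Oc3ccccc3)C(=O)N2c2cc(OC)c(OC)c(OC)c2)cc1` — 6900 nM
compound 2 `COc1cc(N2C(=O)[C@@H](Oc3ccccc3)[C@H]2c2cccc3ccccc23)cc(OC)c1OC` — 53000 nM

In a functional assay on MCF7 cells (Homo sapiens) for antiproliferative activity, read by MTT assay, with stated times of 24 h and 72 h (a lower number here means a stronger inhibitor, a higher number a weaker inhibitor), compound 2 gives 53000 nM, the highest of the two numbers seen. Compound 1 gives 6900 nM, a lower number, and the gap between the two is beyond the scatter. For the measured compounds named here, no single-place step between them is given, so the two values are only noted side by side.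

Compound 3 `COc1cc(N2C(=O)[C@@H](Oc3ccccc3)[C@H]2c2cccc(N)c2)cc(OC)c1OC` has not yet been measured. It differs from compound 2 by 3-aminophenyl in place of naphthalen-1-yl on a saturated ring carbon. Going by the values given here, the only guide is that compound 1, which carries a smaller aryl group at the same saturated ring carbon, sits at 6900 nM, well under compound 2. The step from compound 2 to compound 3 is therefore expected to run downward, to a lower number, and to exceed the scatter: a 6.6-fold lower number from compound 2 to compound 3 (0.82 log units; beyond the scatter). For compound 3 the estimate is 8000 nM, with a range of 2500 nM to 30000 nM, placing it nearer compound 1 than compound 2.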

Compound 3, half-maximal inhibitory concentration: 17000 nM
Beside the measured number, compound 3's estimate is 2.1-fold (0.33 log units) below it, and the stated range covers the measured number.
By their numbers in this assay, from the lowest: compound 1; then compound 3; then compound 2.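

For the compounds shown here, the step of a 3.1-fold lower number from compound 2 to compound 3 (0.49 log units; beyond the scatter) is the first single-place comparison in this assay and is modest in size. It shows that the saturated ring carbon bearing the aryl group responds to the exchange of naphthalen-1-yl for 3-aminophenyl, with the single aromatic ring and its amino group giving the lower number of the pair. The exchange does not reach the lowest number shown, since compound 3 gives 17000 nM and compound 1 gives 6900 nM, the lower of the two, in the same assay, and no measurement shown here bears on the reason for the shift.

The step changes the aromatic ring count and introduces the amino group together, so the contribution of each cannot be separated from these compounds alone. An unsubstituted phenyl at this carbon would help to separate them, while a 3-hydroxyphenyl or 4-aminophenyl group would show whether the amino group and its place on the ring matter at all.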